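Adding a Methyl to the Dihydroxyphenyl of Compound 2

The source may hold more compounds than are shown below. What is called first, only, known or untested is meant among the compounds shown, and "the series" means these compounds.

Three compounds share one core. Compound 1 `CC1(C)CCC[C@]2(C)[C@@H](Cc3ccc(O)cc3O)[C@](C)(O)CC[C@@H]12` gives 10200 nM in a functional assay on HepG2 cells (Homo sapiens) for inhibition, read by MTT assay, with a stated time of 72 h; on this read-out higher numbers stand for an effect only at larger amounts of compound and lower numbers for an effect already at smaller amounts. Compound 2 `CC1(C)CCC[C@]2(C)[C@@H](Cc3c(O)cccc3O)[C@](C)(O)CC[C@@H]12` carries 2,6-dihydroxyphenyl in place of 2,4-dihydroxyphenyl on a saturated chain carbon bound to a saturated ring carbon; in this assay compound 2 gives 13900 nM, and the step of a 1.4-fold higher number from compound 1 to compound 2 (0.13 log units; within the scatter). Compound 3 `Cc1cc(O)cc(O)c1C[C@@H]1[C@@]2(C)CCCC(C)(C)[C@@H]2CC[C@@]1(C)O` carries methyl in place of hydrogen on an aromatic carbon; compound 3 gives 11100 nM, with the step of a 1.1-fold higher number from compound 1 to compound 3 (0.04 log units; within the scatter). Compound 4 `Cc1cc(O)c(C[C@@H]2[C@@]3(C)CCCC(C)(C)[C@@H]3CC[C@@]2(C)O)c(O)c1` is not yet measured and carries methyl in place of hydrogen on an aromatic carbon. This is the same kind of change as in compound 3, but the place differs: in compound 3 the methyl sits ortho to a large group, in compound 4 para to a large group. Beside a 1.1-fold higher number from compound 1 to compound 3 (0.04 log units; within the scatter), the step of a 1.0-fold higher number from compound 2 to compound 4 (0.00 log units; within the scatter) is expected, because compound 2 gives 13900 nM and the earlier methyl step a 1.1-fold higher number from compound 1 to compound 3 (0.04 log units; within the scatter) lay within the scatter. Compound 4 is estimated at 14000 nM, between 7000 nM and 30000 nM.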

Compound 4, half-maximal effective concentration: 10400 nM
Compound 4: the middle estimate sits 1.3-fold (0.13 log units) above what was measured; low and high end bracket the measured number.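

In this assay, methyl in place of hydrogen on an aromatic carbon, para to a large group and meta to two hydroxy groups, gives a 1.3-fold lower number from compound 2 to compound 4 (0.13 log units; within the scatter). Set beside the same change on the core of compound 1, the two steps do not differ: the same change on two cores in this assay, a 1.1-fold higher number (0.04 log units; within the scatter) from compound 1 to compound 3 and a 1.3-fold lower number (0.13 log units; within the scatter) from compound 2 to compound 4, 1.5-fold (0.16 log units) apart, within the scatter of two such steps. In these two pairs the methyl thus leaves the number within the scatter on both cores, but this does not show that the change would behave alike on other cores, and neither step gives a measurable effect of the methyl to carry over.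

Going by these compounds, it stays open whether an ethyl, a methoxy or an amine on that aromatic carbon would move the number beyond the scatter. On these data alone, it also stays open whether the methyl step would hold with methoxy groups in place of the hydroxy groups.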